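A few compounds are considered here, and "the series" means these few. Any claim that something is new, unique, unknown or untested is made for them only; others in the source may bear on it.

Measured so far in an assay on CHO cells for displacement of a labelled ligand from adenosine receptor A1 (Homo sapiens), read by scintillation counting, with a stated time of 120 min, tested at 1 uM; on this read-out lower numbers stand for less inhibition and higher numbers for more inhibition at the one concentration tested (going by the name of the read-out):
- compound 1 `COc1cccc(Nc2nc3c(=O)[nH]c(C)nc3s2)c1`: 8%
- compound 2 `Cc1cccc(Nc2nc3c(=O)[nH]c(C)nc3s2)c1`: 12%

Both numbers are small, and the step of a number 4 percentage points higher from compound 1 to compound 2 (within the scatter) shows that the two compounds cannot be told apart on this read-out; compound 2 simply shares the low level of compound 1 rather than standing apart from it.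

Compound 3 `Cc1nc2sc(Nc3cccc(Cl)c3)nc2c(=O)[nH]1` has not been measured. It differs from compound 2 only in that (chloro in place of methyl on an aromatic carbon). Among the measured compounds shown here, the one step seen so far, a swap of one small group for another at the same place, moved the number only within the scatter. A second swap of that kind, with no change in the shared core, is therefore expected to leave this assay where it is, with no step beyond the scatter in either direction.

The expected step is no change at the digits printed from compound 2 to compound 3 (within the scatter). For compound 3 the estimated value in this assay is 12%, in a range from 0% to 30%.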

Compound 3, a percentage reported as inhibition, at one concentration (the size of the read-out at that concentration, not a potency): 44%
Estimate against measurement, compound 3: 32 percentage points below; the whole stated range lies below it.
By their numbers in this assay, from the lowest: compounds 1 and 2 (each within the scatter of the next); then compound 3.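

In this assay the group on this aromatic carbon, meta to a large group, does matter: chloro in place of methyl gives a number 32 percentage points higher from compound 2 to compound 3 (beyond the scatter) and chloro in place of methoxy gives a number 36 percentage points higher from compound 1 to compound 3 (beyond the scatter) on an unchanged shared core. Chloro and methyl each count as one heavy atom, with no ring, hydrogen-bond donor, hydrogen-bond acceptor or net charge on either, so a change this small by those counts is enough to set compound 3 clear of compound 2. Nothing available explains why chloro stands apart from methyl.

On these data alone, whether the rise belongs to chloro alone or also extends to fluoro, bromo, trifluoromethyl or a nitrile stays open. Also open, as far as these compounds go, is whether chloro would have the same effect elsewhere on this ring.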